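Methoxy for Methyl on Two Cores

The source may report more compounds than this note shows. Statements on the series, on what has been measured and on what is new or still open speak of the compounds shown alone.

Three compounds have been measured in an assay on isolated protein for inhibition of Aromatase (Homo sapiens), read by fluorescence and colorimetric assay, with a stated time of 30 min; a higher number here means a weaker inhibitor, a lower number a stronger inhibitor:

compound 1, `Cc1ccc(OCc2cn(C(c3ccc(C#N)cc3)c3ccc(C#N)cc3)nn2)cc1`, where compound 1 gives 11000 nM
compound 2, `COc1ccc(OCc2cn(C(c3ccc(C#N)cc3)c3ccc(C#N)cc3)nn2)cc1`, where compound 2 gives 12200 nM
compound 3, `Cc1ccc(OCc2cn(Cc3ccccc3)nn2)cc1`, where compound 3 gives 2270 nM

Compound 1 and compound 2 share one core, while compound 3 is built on another; the difference between the two cores is not broken down here. Compound 3 gives a lower number than compound 1 and than compound 2, and both of those gaps lie beyond the usual scatter, so compound 3 is the strongest inhibitor of the three.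

Within the first core, compound 2 differs from compound 1 by methoxy in place of methyl on an aromatic carbon. That change produced a 1.1-fold higher number from compound 1 to compound 2 (0.04 log units; within the scatter), which is within the scatter, so the two values show no real change.

Compound 4, `COc1ccc(OCc2cn(Cc3ccccc3)nn2)cc1`, is the unmeasured partner of compound 3 and differs from it by methoxy in place of methyl on an aromatic carbon. The place of the change is described in the same words for both pairs, so this is the same change carried onto the second core.

The expected step is a 1.1-fold higher number from compound 3 to compound 4 (0.04 log units; within the scatter), because the same change on the other core gave a 1.1-fold higher number from compound 1 to compound 2 (0.04 log units; within the scatter). Going by the values given here, there is only this one measured instance to rest on, and the second core is not identical, so the range is kept wide. Compound 4 is therefore expected to give about 2500 nM, most likely between 1200 nM and 5500 nM.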

Compound 4, half-maximal inhibitory concentration: 17300 nM
For compound 4 the middle estimate is 6.9-fold (0.84 log units) below the measured one, outside the stated range (above it).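

On the second core, methoxy in place of methyl gave a 7.6-fold higher number from compound 3 to compound 4 (0.88 log units; beyond the scatter) in this assay, so the change that left the first core without a real shift clearly weakens inhibition here. Set side by side, the two instances of this change do not agree, which shows that in this series its effect on one core cannot be carried over to the other as it stands: the same change on two cores in this assay, a 1.1-fold higher number (0.04 log units; within the scatter) from compound 1 to compound 2 and a 7.6-fold higher number (0.88 log units; beyond the scatter) from compound 3 to compound 4, 6.9-fold (0.84 log units) apart, beyond the scatter of two such steps. The result does not show which feature of the two cores separates the outcomes, nor what lies behind the gap, and two pairs give no rule for any further core.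

The compounds shown leave open how other groups on the same aromatic carbon, such as a chlorine atom, a hydroxyl, an amine or a longer ether chain like ethoxy, would behave on either core. They also leave open whether such replacements would split between the two cores in the same way as methoxy, or whether that split is confined to this one change.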